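The source may report more compounds than this note shows. Statements on the series, on what has been measured and on what is new or still open speak of the compounds shown alone.

Working notes on the series. The shared core is that of compound 1 `CCOC(=O)c1c(-c2cccc(C)c2)csc1N`; compound 2 `CCOC(=O)c1c(-c2cccc(NC(C)=O)c2)csc1N` and the yet unmeasured compound 3 `CCOC(=O)c1c(-c2cccc(C(F)(F)F)c2)csc1N` carry it unchanged and differ only in the group on the six-membered aromatic ring of carbon only. Going by the values given here, in an assay on isolated protein for inhibition of protein kinase C zeta type (Homo sapiens), with stated times of 1 h and 2.5 min, tested at 30 uM (a lower number here means less inhibition, a higher number more inhibition at the concentration tested (going by the name of the read-out)), compound 1 gives 77%, and compound 2 gives 89%, the highest of the two numbers measured so far, the only other one being compound 1 at the step of a number 12 percentage points higher from compound 1 to compound 2 (beyond the scatter). The step to compound 3 is trifluoromethyl in place of acetamido on an aromatic carbon. Among the compounds with values here, only one measured step bears on it, the modest gain a number 12 percentage points higher from compound 1 to compound 2 (beyond the scatter) on going to acetamido from a group that, like the trifluoromethyl entering here, has no hydrogen-bond donor or acceptor. Reversing that direction, a step of about the same size downward is expected, a number 13 percentage points lower from compound 2 to compound 3 (beyond the scatter), so compound 3 is estimated at 76% with a range from 58% to 90%.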

Compound 3, a percentage reported as inhibition, at one concentration (the size of the read-out at that concentration, not a potency): 30%
For compound 3 the middle estimate is 46 percentage points above the measured one; the whole stated range lies above it.
By their numbers in this assay, from the lowest: compound 3; then compound 1; then compound 2.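

In this assay this place on the six-membered aromatic ring proves far more sensitive to the group it carries than the first pair showed: trifluoromethyl in place of acetamido, with the same number of heavy atoms, costs much of the inhibition (a number 59 percentage points lower from compound 2 to compound 3 (beyond the scatter)). Lacking a hydrogen-bond donor or acceptor does not by itself set the level, since methyl also lacks both, yet trifluoromethyl in place of methyl is still a large loss (a number 47 percentage points lower from compound 1 to compound 3 (beyond the scatter)). No measurement at hand explains the loss.

Still open, going by these compounds, is whether an amino group or a carboxylic acid at this place would hold inhibition near that of compound 2, or fall toward that of compound 3. Each number also stands at one concentration, so the potency of these compounds remains open.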